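The source may hold more compounds than are shown below. What is called first, only, known or untested is meant among the compounds shown, and "the series" means these compounds.

Compound 1 `CO/N=C(\C)c1ccc(Sc2cc(F)cc(C3CCOCC3)c2)cc1`: 110 nM
Compound 2 `CCOC(=O)c1csc(CO/N=C(\C)c2ccc(Sc3cc(F)cc(C4CCOCC4)c3)cc2)n1`: 150 nM
Compound 3 `O/N=C(/c1ccc(Sc2cc(F)cc(C3CCOCC3)c2)cc1)C(F)(F)F`: 280 nM

In a functional assay (blood) for inhibition, with Homo sapiens as the target (on this read-out higher numbers stand for weaker inhibition and lower numbers for stronger inhibition), compound 1 gives the lowest of the three numbers shown; compound 2 sits nearest, with a 1.4-fold higher number from compound 1 to compound 2 (0.13 log units; within the scatter), and compound 3 furthest, with a 2.5-fold higher number from compound 1 to compound 3 (0.41 log units; beyond the scatter). Compound 4 `CO/N=C(\C)c1ccc(Sc2cc(F)cc([C@@]3(OC)CCO[C@@H](C)C3)c2)cc1` differs from compound 1 in one place: 4-methoxy-2-methyloxan-4-yl in place of oxan-4-yl on an aromatic carbon. Neither measured step touches this part of the shared core; both alter other positions, one within the scatter and one modest. Among the measured compounds shown here, no measured step therefore bears directly on the change to compound 4, and the expected movement in this assay is none beyond the scatter, with a slight lean towards a higher number. The expected step is a 1.4-fold higher number from compound 1 to compound 4 (0.13 log units; within the scatter). Compound 4 is thus estimated at 150 nM, within 50 nM to 450 nM.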

Compound 4, half-maximal inhibitory concentration: 140 nM
The estimate for compound 4 lay 1.1-fold (0.03 log units) above the measured number; low and high end bracket the measured number.
By their numbers in this assay, from the lowest: compounds 1, 4, 2 and 3 (each within the scatter of the next, the first and the last beyond it).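

In this assay the swap of oxan-4-yl for 4-methoxy-2-methyloxan-4-yl on the aromatic carbon gives a 1.3-fold higher number from compound 1 to compound 4 (0.10 log units; within the scatter) and so stays within the scatter. This is the first change shown at this position, which here takes the larger group, with its added hydrogen-bond acceptor and two defined stereocentres, without a step beyond the scatter. No measurement at hand explains this result.

Still open, from the compounds shown here alone, is whether 4-methoxyoxan-4-yl or 2-methyloxan-4-yl alone would behave the same way, and how the other stereoisomers compare. An amine or a carboxylic acid at this position also remains untested among the compounds shown.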